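Ethyl on the Carbamoyl of Compound 2

A few compounds are considered here, and "the series" means these few. Any claim that something is new, unique, unknown or untested is made for them only; others in the source may bear on it.

In a functional assay on HCT-116 cells (Homo sapiens) for inhibition (on this read-out higher numbers stand for weaker inhibition and lower numbers for stronger inhibition), compound 1 (`CCCNCc1cc(-c2c(C(=O)NCC)noc2-c2cc(C(C)C)c(O)cc2O)on1`) gives 117 nM and compound 2 (`CCNC(=O)c1noc(-c2cc(C(C)C)c(O)cc2O)c1-c1cc(C(N)=O)no1`) gives 79 nM. Within the data shown here, these two numbers lie within the usual scatter of repeated measurements, so compound 2 stands level with compound 1, its only measured neighbour.

Compound 3 (`CCNC(=O)c1cc(-c2c(C(=O)NCC)noc2-c2cc(C(C)C)c(O)cc2O)on1`) differs from compound 2 in one place. Ethyl takes the place of hydrogen on an amide-type nitrogen, which turns carbamoyl into ethylcarbamoyl (ethyl in place of hydrogen on an amide-type nitrogen).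

Among the measured compounds shown here, no measured pair tests this exact change, so the evidence is indirect. For the measured compounds named here, the one measured step, a 1.5-fold lower number from compound 1 to compound 2 (0.17 log units; within the scatter), puts carbamoyl in place of (propylamino)methyl on an aromatic carbon and stays within the scatter. It involves the same carbamoyl group, and exchanging that whole group left the number within the scatter. As far as these compounds go, on this single comparison, no shift beyond the scatter is anticipated in this assay, and the direction remains open.

The expected step is a 1.1-fold higher number from compound 2 to compound 3 (0.06 log units; within the scatter), which is an estimate and not a measurement. In this assay, the estimate for compound 3 is 90 nM, with an expected range of 40 nM to 200 nM.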

Compound 3, half-maximal inhibitory concentration: 14 nM
Beside the measured number, compound 3's estimate is 6.4-fold (0.81 log units) above it; the measured number lies below the stated range.
By their numbers in this assay, from the lowest: compound 3; then compounds 2 and 1 (each within the scatter of the next).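

In this assay, ethyl in place of hydrogen on the amide-type nitrogen gives a 5.6-fold lower number from compound 2 to compound 3 (0.75 log units; beyond the scatter) and so moves the number clearly, which shows that this nitrogen is a sensitive place in the molecule. The earlier pair could not show this: carbamoyl and (propylamino)methyl sat level with each other, so the group on this aromatic carbon seemed to make little difference. The ethylcarbamoyl group changes that picture with an 8.4-fold lower number from compound 1 to compound 3 (0.92 log units; beyond the scatter) and leaves compound 3 with the lowest number of the three, so the ethyl on the nitrogen, and not the carbonyl alone, sets compound 3 apart from compound 2.

Still open, as far as these compounds go, is whether a methyl, a longer chain such as propyl or butyl, or a cyclopropyl ring on the same nitrogen would lower the number further, or whether a carboxylic acid in place of the amide would keep any of this strength. No measurement among these data accounts for the drop that ethyl brings.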